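The source may report more compounds than this note shows. Statements on the series, on what has been measured and on what is new or still open speak of the compounds shown alone.

Measured in a functional assay on A-375 cells (Homo sapiens) for antiproliferative activity, read by MTT assay, with a stated time of 72 h; a lower number here means a stronger inhibitor, a higher number a weaker inhibitor:
- compound 1 `COc1ccc(N2C(=O)COc3ccc(-c4cnc(Cl)c(NS(=O)(=O)c5ccc(F)cc5)c4)cc32)cc1`: 32700 nM
- compound 2 `COc1ncc(-c2ccc3c(c2)N(C2CCCCC2)C(=O)CO3)cc1NS(=O)(=O)c1ccc(F)cc1`: > 40000 nM
- compound 3 `COc1cccc(N2C(=O)COc3ccc(-c4cnc5ccccc5c4)cc32)c1`: 23600 nM

Compound 3 gives 23600 nM and compound 1 gives 32700 nM, two values within the scatter of each other. Compound 2 gives > 40000 nM, which is a limit of the assay and not a number.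

Compound 4 `O=C1COc2ccc(-c3cnc4ccccc4c3)cc2N1c1ccc(Cl)cc1` carries 4-chlorophenyl in place of 3-methoxyphenyl on an amide-type nitrogen in a ring. Among the measured compounds shown here, no measured pair shows this change, so the only anchor is compound 3 at 23600 nM. The step expected in this assay is a 1.1-fold higher number from compound 3 to compound 4 (0.03 log units; within the scatter), with nothing beyond the scatter anticipated. For compound 4 the estimated value is 25000 nM, with an expected range from 9000 nM to 40000 nM.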

Compound 4, half-maximal inhibitory concentration: > 40000 nM
Compound 4: no number, only a limit; the forecaster's own chance of this, stated with the estimate: 25%; middle value at least 1.6-fold (0.20 log units) from the limit.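

Placing 4-chlorophenyl in place of 3-methoxyphenyl on the amide-type nitrogen gives the first single-place reading at this position in this assay, an at least 1.6-fold higher number from compound 3 to compound 4 (0.22 log units; that floor lies within the scatter). Compound 4 gives a limit of the assay and not a number, so only a floor for this step is known. The change brings no lower number, and the reading is capped by the assay's upper limit: the limit of > 40000 nM in this assay, at which 2 of the 4 values shown sit.

The compounds shown do not separate the swap of methoxy for chlorine from the shift in ring placement. A 3-chlorophenyl or an unsubstituted phenyl on this nitrogen would bear on both questions.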